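From 2-chloro-4-fluorobenzyl to 3-chloro-4-fluorobenzyl

The compounds below may be only part of what the source reports. "The series", "measured", "known", "first", "only" and "open" are said of these compounds alone.

In a functional assay on CCRF-CEM cells (Homo sapiens) for antiproliferative activity, with a stated time of 72 h (a lower number here means a stronger inhibitor, a higher number a weaker inhibitor), three compounds sharing one core have been measured. Compound 1 `OC[C@H]1O[C@@H](n2cnc3c(NCc4ccc(Cl)cc4)ncnc32)[C@H](O)[C@@H]1O` gives 10200 nM, compound 2 `OC[C@H]1O[C@@H](n2cnc3c(NCc4ccc(F)cc4F)ncnc32)[C@H](O)[C@@H]1O` gives 7100 nM, and compound 3 `OC[C@H]1O[C@@H](n2cnc3c(NCc4ccc(F)cc4Cl)ncnc32)[C@H](O)[C@@H]1O` gives 20900 nM, the highest number of the three. Compound 4 `OC[C@H]1O[C@@H](n2cnc3c(NCc4ccc(F)c(Cl)c4)ncnc32)[C@H](O)[C@@H]1O` has the same atoms as compound 3 but carries 3-chloro-4-fluorophenyl in place of 2-chloro-4-fluorophenyl on a saturated chain carbon bound to a nitrogen on an aromatic ring. For the measured compounds named here, no measured step makes this exact change, so the evidence is indirect. Two steps reach the 2-chloro-4-fluorophenyl group: a 2.0-fold higher number from compound 1 to compound 3 (0.31 log units; beyond the scatter) and a 2.9-fold higher number from compound 2 to compound 3 (0.47 log units; beyond the scatter). Both are modest, while a 1.4-fold lower number from compound 1 to compound 2 (0.16 log units; within the scatter) stays within the scatter. On that basis, a modest move to a lower number is expected in this assay. The estimated step is a 2.1-fold lower number from compound 3 to compound 4 (0.32 log units; beyond the scatter). For compound 4 the estimated value is 10000 nM, with an expected range of 4000 nM to 24000 nM.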

Compound 4, half-maximal inhibitory concentration: 3400 nM
Beside the measured number, compound 4's estimate is 2.9-fold (0.47 log units) above it, and the stated range ends above it.
By their numbers in this assay, from the lowest: compound 4; then compounds 2 and 1 (each within the scatter of the next); then compound 3.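

In this assay, rearranging the same atoms from 2-chloro-4-fluorophenyl to 3-chloro-4-fluorophenyl gives a 6.1-fold lower number from compound 3 to compound 4 (0.79 log units; beyond the scatter), the largest step among the four compounds. The earlier compounds had shown this chlorine- and fluorine-bearing phenyl group only in the form that gave the highest number, whereas the same two halogens arranged as 3-chloro-4-fluorophenyl give the lowest. The new group also improves on both other groups, with a 2.1-fold lower number from compound 2 to compound 4 (0.32 log units; beyond the scatter) and a 3.0-fold lower number from compound 1 to compound 4 (0.48 log units; beyond the scatter), which makes compound 4 the strongest inhibitor of the four.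

Whether a 3-chloro-4-fluorophenyl group is needed for this level of activity stays open, as the compounds shown include no phenyl group with methoxy in place of its chlorine. Nothing at hand accounts for the size of the step from the 2-chloro-4-fluorophenyl group.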